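One More Phenyl on the Amide Side Chain

A few compounds are considered here, and "the series" means these few. Any claim that something is new, unique, unknown or untested is made for them only; others in the source may bear on it.

compound 1 `CCOc1nc2cccc(C(=O)Nc3ccc(OC)cc3)c2n1Cc1ccc(-c2ccccc2-c2nnn[nH]2)cc1` gives 25.8% in an assay on isolated protein for inhibition of NEDD8-activating enzyme E1 regulatory subunit (Homo sapiens), read by Western blot, with stated times of 10 min and 30 min, tested at 25 uM; on this read-out higher numbers stand for more inhibition at the one concentration tested (going by the name of the read-out) and lower numbers for less inhibition
compound 2 `CCOc1nc2cccc(C(=O)NCc3ccco3)c2n1Cc1ccc(-c2ccccc2-c2nnn[nH]2)cc1` gives 37.5%
compound 3 `CCOc1nc2cccc(C(=O)NCc3ccccc3)c2n1Cc1ccc(-c2ccccc2-c2nnn[nH]2)cc1` gives 48.9%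

Compound 3 stands highest of the three, with compound 2 nearest and compound 1 furthest, both gaps beyond the scatter. Compound 4 `CCOc1nc2cccc(C(=O)NC(c3ccccc3)c3ccccc3)c2n1Cc1ccc(-c2ccccc2-c2nnn[nH]2)cc1` differs from compound 3 by phenyl in place of hydrogen on a saturated chain carbon bound to an amide-type nitrogen and an aromatic carbon. Within the data shown here, the steps that bear on this are a number 11.4 percentage points higher from compound 2 to compound 3 (beyond the scatter) and a number 23.1 percentage points higher from compound 1 to compound 3 (beyond the scatter), both modest rises as the group on the amide nitrogen changes toward a benzyl. Among the measured compounds shown here, a second phenyl on the same carbon continues in that direction, and a further modest rise is expected, though only three compounds support this and the range is kept wide. Compound 4 is therefore expected to give 55%, between 35% and 75%, an expected step of a number 6.1 percentage points higher from compound 3 to compound 4 (within the scatter).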

Compound 4, a percentage reported as inhibition, at one concentration (the size of the read-out at that concentration, not a potency): 35.7%
Compound 4: middle estimate off by 19.3 percentage points, on the high side; the measured number falls inside the stated range.
By their numbers in this assay, from the lowest: compounds 1, 4 and 2 (each within the scatter of the next, the first and the last beyond it); then compound 3.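

Phenyl in place of hydrogen on this saturated chain carbon gives a number 13.2 percentage points lower from compound 3 to compound 4 (beyond the scatter), so in this assay the rise seen on reaching the benzyl of compound 3 does not continue when a second phenyl is added to the same carbon. The benzyl of compound 3 thus stands above this larger group, showing that more aromatic ring here does not by itself bring more inhibition. Nothing available explains this fall.

Going by these compounds, it remains open whether a methyl on this carbon would keep the number, and whether a longer chain, such as 2-phenylethyl on the amide-type nitrogen, would raise it.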